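The compounds below may be only part of what the source reports. "The series", "measured", "known", "first", "only" and "open" are said of these compounds alone.

Compound 1 `Cc1nn(-c2ncnc3nc[nH]c23)c2c1C(OC(=O)c1ccc(F)cc1)CC(=O)N2`, compound 2 `C=CCN1c2c(n(C)c(=O)n(C)c2=O)NC1N/N=C/c1ccc(O)cc1O` and compound 3 `Cc1nn(-c2ncnc3nc[nH]c23)c2c1C(C(=O)NCc1ccc(F)cc1)CC(=O)N2` have all been tested in a functional assay on HEK293 cells for agonist activity at G-protein coupled receptor 39 (Homo sapiens), read by scintillation proximity assay and inositol phosphate accumulation, with a stated time of 75 min, in the presence of a further agent that is not named here; a lower number here means that less compound is needed, a higher number that more compound is needed for the effect. In this assay compound 1 gives 4 nM, and compound 3 gives 4 nM; these two are level within the scatter and together are the lowest of the three numbers. Compound 2 gives 340 nM, a much higher number, so much more of it is needed for the same effect. The next compound, compound 4 `Cc1nn(-c2ncnc3nc[nH]c23)c2c1C(OCc1ccc(F)cc1)CC(=O)N2`, differs from compound 1 in one place: 4-fluorobenzyl in place of (4-fluorophenyl)carbonyl on an oxygen on a saturated carbon. The (4-fluorophenyl)carbonyl leaves and 4-fluorobenzyl enters on the same oxygen. Because compound 3 keeps 4 nM with a different linking group, only a modest rise is expected here, a 3.8-fold higher number from compound 1 to compound 4 (0.57 log units; beyond the scatter). Compound 4 is therefore expected to give about 15 nM, with a likely range from 3 nM to 80 nM.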

Compound 4, half-maximal effective concentration: 1 nM
Compound 4: the middle estimate sits 15-fold (1.18 log units) above what was measured, outside the stated range (below it).
By their numbers in this assay, from the lowest: compound 4; then compounds 1 and 3 (each within the scatter of the next); then compound 2.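

Swapping the (4-fluorophenyl)carbonyl on this oxygen for 4-fluorobenzyl gives a 4.0-fold lower number from compound 1 to compound 4 (0.60 log units; beyond the scatter) in this assay. So at this position, the carbonyl of compound 1 is not required for a low number, and the change from ((4-fluorophenyl)carbonyl)oxy to (4-fluorobenzyl)oxy lowers it modestly. The compounds shown leave open how a plain benzyl without the fluorine, or a longer chain such as 2-(4-fluorophenyl)ethyl, would read on this same oxygen. Nothing measured here gives a reason for the step.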